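This account rests on a few compounds, and the source may have more. Where it says the series, first, only, none or still open, it means among the compounds named here.

Compound 2 `Nc1nn(C(=O)Nc2ccc(Cc3ccccc3)cc2)c2ccc(Cl)cc12` carries a chloro group on the shared core of compound 1 `Nc1nn(C(=O)Nc2ccc(Cc3ccccc3)cc2)c2ccccc12`. In a functional assay on BT-549 cells (Homo sapiens) for antiproliferative activity, read by sulforhodamine B assay, with a stated time of 48 h (a higher number here means that more compound is tolerated, a lower number that less compound is tolerated), compound 1 gives only a limit of the assay, > 100000 nM. In this assay compound 2 likewise gives only a limit, > 100000 nM. Both values sit at the limit of > 100000 nM in this assay, at which 2 of the 2 values shown sit, so the size of the step that the two limits leave unreadable from compound 1 to compound 2 cannot be read. Compound 3 `Nc1ccc2c(c1)c(N)nn2C(=O)Nc1ccc(Cc2ccccc2)cc1` replaces the chloro group with an amino group: amino in place of chloro on an aromatic carbon. For the measured compounds named here, the only measured step that bears on this change is the one from compound 1 to compound 2, and its size is hidden by the two limits, so no direction in this assay can be drawn from it. With both measured compounds at the limit, compound 3 is expected to tolerate a similar amount, an estimated step of a number no higher from compound 2 to compound 3 (the limit leaves the size open). The estimate for compound 3 is 100000 nM, between 20000 nM and 300000 nM, and it is expected most likely to be reported again only as a limit.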

Compound 3, concentration lethal to 50% of the cells: 76700 nM
Compound 3: the middle estimate sits 1.3-fold (0.12 log units) above what was measured, within the range that was stated.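

In this assay compound 3 gives 76700 nM, the first real number among the compounds shown rather than a limit, so with an amino group on this aromatic carbon the value falls within what the assay can read. Amino in place of chloro gives an at least 1.3-fold lower number from compound 2 to compound 3 (0.11 log units; that floor lies within the scatter), and amino in place of hydrogen gives an at least 1.3-fold lower number from compound 1 to compound 3 (0.11 log units; that floor lies within the scatter). On these data alone, each figure starts from a limit and is only a floor, so the true size of either step stays unknown.

As far as these compounds go, a single amino compound sets no pattern, and whether another group on this carbon, such as a hydroxyl or a carboxylic acid, would also give a readable value stays open. How far the amino group really moves the value cannot be settled while the other compounds stay at the limit: the limit of > 100000 nM in this assay, at which 2 of the 3 values shown sit.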